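A Methoxy Step Carried Over to a Second Core

A few compounds are considered here, and "the series" means these few. Any claim that something is new, unique, unknown or untested is made for them only; others in the source may bear on it.

Compound 1 `Cc1[nH]c2ccccc2c(=O)c1Cc1ccccc1` was measured in an ADME assay for permeability, using PAMPA, at pH 7.4 (on this read-out higher numbers stand for higher permeability and lower numbers for lower permeability), where compound 1 gives 102 10^-6 cm/s. Two compounds built on another core were measured as well: compound 3 `CCCCC#Cc1c(C)[nH]c2ccccc2c1=O` gives 2140 10^-6 cm/s, and compound 2 `CCCCC#Cc1c(C)[nH]c2ccc(OC)cc2c1=O` gives 2440 10^-6 cm/s. Compound 1 has the lowest number of the three; compound 3 stands nearest to it and compound 2 furthest away, both beyond the scatter. How the core of compound 1 differs from the core of compound 3 is not broken down here.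

Compound 2 differs from compound 3 in one place, methoxy in place of hydrogen on an aromatic carbon and this change made a step of a 1.1-fold higher number from compound 3 to compound 2 (0.06 log units; within the scatter). Compound 4 `COc1cccc2[nH]c(C)c(Cc3ccccc3)c(=O)c12`, not yet measured, differs from compound 1 by the same kind of change, (methoxy in place of hydrogen on an aromatic carbon). The place is not the same: in compound 2 the methoxy sits meta to a fused ring and para to a fused ring, while in compound 4 it sits ortho to a fused ring and meta to a fused ring. For compound 4 a step of a 1.1-fold higher number from compound 1 to compound 4 (0.03 log units; within the scatter) is expected, resting on the earlier step of a 1.1-fold higher number from compound 3 to compound 2 (0.06 log units; within the scatter) made by the same kind of change. Compound 4 is therefore estimated to give 110 10^-6 cm/s, with a range from 50 10^-6 cm/s to 240 10^-6 cm/s.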

Compound 4, apparent permeability: 158 10^-6 cm/s
Estimate against measurement, compound 4: 1.4-fold (0.16 log units) below, within the range that was stated.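

In this assay, methoxy in place of hydrogen on an aromatic carbon of the core of compound 1 made a step of a 1.5-fold higher number from compound 1 to compound 4 (0.19 log units; within the scatter). Set beside the same change on the other core, the two steps agree, so in this small set the change carried over from one core to the other without a step beyond the scatter: the same change on two cores in this assay, a 1.1-fold higher number (0.06 log units; within the scatter) from compound 3 to compound 2 and a 1.5-fold higher number (0.19 log units; within the scatter) from compound 1 to compound 4, 1.4-fold (0.13 log units) apart, within the scatter of two such steps. This does not show that the change behaves alike wherever it is made, as the methoxy does not sit in the same place in compound 2 and compound 4, which leaves core and place unseparated, and two cores say nothing about a third.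

Still open, as far as these compounds go, is what methoxy gives on each core when it sits in the place it holds on the other core. Also open, from the compounds shown here alone, is whether a different group on the same aromatic carbon, such as an amine, a carboxylic acid or a longer chain like butoxy, would stay as close to its parent compound as methoxy does here.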